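Chloro for fluoro on the sulfonamide ring

The source may report more compounds than this note shows. Statements on the series, on what has been measured and on what is new or still open speak of the compounds shown alone.

Of the compounds shown here, two have been measured in a functional assay on HepG2 cells (Homo sapiens) for antiproliferative activity, read by MTT assay, with a stated time of 72 h; on this read-out lower numbers stand for stronger inhibition and higher numbers for weaker inhibition. Compound 1, `O=C1O/C(=C\Cn2cc(-c3cc(F)cc(F)c3)nn2)C(OCc2ccccc2)=C1OCc1ccccc1`, gives > 100000 nM, which is a limit of the assay rather than a number. Going by the values given here, compound 2, `O=C1O[C@H]([C@@H](O)Cn2cc(CNS(=O)(=O)c3ccc(F)cc3)nn2)C(OCc2ccccc2)=C1OCc1ccccc1`, gives 18300 nM in this assay, the only true number among the two values. The other value, that of compound 1, is a limit (the limit of > 100000 nM in this assay, at which 1 of the 2 values shown sits).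

Compound 3, `O=C1O[C@H]([C@@H](O)Cn2cc(CNS(=O)(=O)c3ccc(Cl)cc3)nn2)C(OCc2ccccc2)=C1OCc1ccccc1`, differs from compound 2 in a single place: chloro in place of fluoro on an aromatic carbon of a six-membered aromatic ring of carbon only, para to a large group. Among the compounds with values here, no measured pair in this set carries this kind of exchange, so there is no step to lean on. Such a swap of one halogen for another on an aromatic carbon is expected to move the value little, if at all, beyond the usual scatter, with the direction unknown.

Starting from compound 2 at 18300 nM, compound 3 is expected to give 13000 nM in this assay, within a range of 4500 nM to 40000 nM, a step of a 1.4-fold lower number from compound 2 to compound 3 (0.15 log units; within the scatter) that is expected to stay close to the measured value of compound 2.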

Compound 3, half-maximal inhibitory concentration: 7510 nM
The estimate for compound 3 lay 1.7-fold (0.24 log units) above the measured number; measured number inside the range.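

In this assay, chloro in place of fluoro on an aromatic carbon, para to a large group, gives a 2.4-fold lower number from compound 2 to compound 3 (0.39 log units; beyond the scatter), which shows that this place on the sulfonamide ring responds to the exchange of one halogen for another. Going by these compounds alone, the step is modest, yet it is the only measured step in this set between compounds that differ in one place, and it comes with no change in the count of rings, hydrogen-bond donors or hydrogen-bond acceptors, and no change in net charge. Nothing in the data shown accounts for the size or the direction of this step.

As far as these compounds go, only these two halogens stand at this place, so it remains open how the number would move with bromo, methoxy, an amine or a carboxylic acid there, or with plain hydrogen in their stead. From the compounds shown here alone, it also remains open whether the same exchange would give a similar step at another carbon of this ring, or in compounds that differ from compound 2 and compound 3 elsewhere in the molecule.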